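Removing the Ring Methyl: Expected Effect on Tolerated Concentration

This account rests on a few compounds, and the source may have more. Where it says the series, first, only, none or still open, it means among the compounds named here.

Compound 1 `CCN(CC)CC(=O)Nc1ccc(-c2nc3cc(C(F)(F)F)ccc3n2C)cc1` is the starting point. In an ADME assay on Vero cells (Chlorocebus sabaeus) for cytotoxicity (a higher number here means that more compound is tolerated, a lower number that less compound is tolerated), compound 1 gives 90000 nM. Compound 2 `CCN(CC)CC(=O)Nc1ccc(-c2nc3cc(C(F)(F)F)ccc3[nH]2)cc1` differs from it only by hydrogen in place of methyl on an aromatic nitrogen, and in this assay compound 2 gives 24000 nM, which is a 3.8-fold lower number from compound 1 to compound 2 (0.57 log units; beyond the scatter). Compound 3 `Cn1c(-c2ccc(NC(=O)CN3CCN(c4ccccc4)CC3)cc2)nc2cc(C(F)(F)F)ccc21` keeps the methyl but carries another side chain, (4-phenylpiperazin-1-yl in place of diethylamino on a saturated chain carbon bound to a carbonyl carbon); in this assay compound 3 gives 30000 nM, which is a 3.0-fold lower number from compound 1 to compound 3 (0.48 log units; beyond the scatter).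

Compound 4 `O=C(CN1CCN(c2ccccc2)CC1)Nc1ccc(-c2nc3cc(C(F)(F)F)ccc3[nH]2)cc1` has not yet been measured. It differs from compound 3 by hydrogen in place of methyl on an aromatic nitrogen, the same change that turns compound 1 into compound 2, made at the same place on the shared core. Compound 1 and compound 2 show a 3.8-fold lower number from compound 1 to compound 2 (0.57 log units; beyond the scatter). A step of roughly that size is expected for compound 4, a 3.8-fold lower number from compound 3 to compound 4 (0.57 log units; beyond the scatter). This expectation rests on a single pair, so it is held loosely. The expected result for compound 4 in this assay is 8000 nM, with a plausible range from 3000 nM to 25000 nM.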

Compound 4, half-maximal cytotoxic concentration: > 100000 nM
Compound 4 ended at the assay's limit; the forecaster's own chance of this, stated with the estimate: 10%; middle value at least 12-fold (1.09 log units) away from the limit.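

In this assay, hydrogen in place of methyl on the aromatic nitrogen does not carry over from one core to the other, since the direction reverses with an at least 3.3-fold higher number from compound 3 to compound 4 (0.52 log units; beyond the scatter) and the two steps differ clearly: the same change on two cores in this assay, a 3.8-fold lower number (0.57 log units; beyond the scatter) from compound 1 to compound 2 and an at least 3.3-fold higher number (0.52 log units; beyond the scatter) from compound 3 to compound 4, at least 12-fold (1.09 log units) apart, beyond the scatter of two such steps. Compound 4 stands at a limit of the assay, so its step has a known direction but no known full size: the limit of > 100000 nM in this assay, at which 1 of the 4 values shown sits. Going by these compounds alone, with only two pairs, this shows that the effect of the change on tolerated concentration depends here on what else the molecule carries, but it does not show why, and it gives no rule for any other side chain.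

The compounds shown carry only a diethylamino or a 4-phenylpiperazin-1-yl group on the chain, so it remains open which way the same change would go with a morpholine or a simple dimethylamino group there. On these data alone, it also remains open whether an ethyl group on the aromatic nitrogen would behave like the methyl or like the hydrogen on either core.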